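The compounds below may be only part of what the source reports. "The series", "measured", "known", "first", "only" and "open" are said of these compounds alone.

Compounds measured so far:
compound 1, `CCCOc1cccnc1-c1ccc(C(=O)Nc2ccc(C(C)(C)C)cc2)cc1`, with 62 nM
compound 2, `CC(C)(C)c1ccc(NC(=O)c2ccc(-c3ncccc3NS(C)(=O)=O)cc2)cc1`, with 152 nM

In a functional assay for antagonist activity at transient receptor potential cation channel subfamily V member 1 (Homo sapiens), read by FLIPR (a lower number here means a stronger inhibitor, a higher number a weaker inhibitor), compound 2 gives the higher of the two numbers recorded; its nearest neighbour is compound 1, separated by a 2.5-fold higher number from compound 1 to compound 2 (0.39 log units; beyond the scatter), a change of methanesulfonamido in place of propoxy on an aromatic carbon.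

Compound 3, `CC(C)(C)c1ccc(NC(=O)c2ccc(-c3ncccc3N(S(C)(=O)=O)S(C)(=O)=O)cc2)cc1`, is not yet measured. It differs from compound 2 by methylsulfonyl in place of hydrogen on a sulfonamide nitrogen; the same change cut one bond further out reads methanesulfonamido to bis(methylsulfonyl)amino.

Among the compounds with values here, the single measured step, from compound 1 to compound 2, concerns the group on the aromatic carbon and not a substitution on the sulfonamide nitrogen, so it bears only loosely on the present step. Within the data shown here, no measured pair shows what a second methylsulfonyl on that nitrogen does. Given that compound 2 already sits at the weaker end, the working expectation is a modest further rise in this assay, though a result within the scatter cannot be excluded.

Compound 3 is therefore expected to give about 400 nM, with a plausible range of 120 nM to 1500 nM, which corresponds to an estimated step of a 2.6-fold higher number from compound 2 to compound 3 (0.42 log units; beyond the scatter).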

Compound 3, half-maximal inhibitory concentration: 0.8 nM
Compound 3: middle estimate off by 500-fold (2.70 log units), on the high side; the measured number lies below the stated range.
By their numbers in this assay, from the lowest: compound 3; then compound 1; then compound 2.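

In this assay, the sulfonamide nitrogen proves a highly sensitive place: methylsulfonyl in place of hydrogen there gives a 190-fold lower number from compound 2 to compound 3 (2.28 log units; beyond the scatter), a far larger step than the only earlier one and opposite in direction. Measured against propoxy on the same aromatic carbon, bis(methylsulfonyl)amino gives a 78-fold lower number from compound 1 to compound 3 (1.89 log units; beyond the scatter), so a replacement of propoxy that raised the number as methanesulfonamido lowers it strongly once the nitrogen carries a second methylsulfonyl. Nothing in the data shown accounts for the size of this step.

From the compounds shown here alone, it remains open whether the gain is specific to a second methylsulfonyl or would also follow from a simple methyl, an acetyl or an ethylsulfonyl on that nitrogen, any of which would separate the effect of replacing the sulfonamide hydrogen from that of adding a sulfonyl group. Within the data shown here, it also remains open whether a longer chain on the sulfonyl groups would be accepted, and whether a step of this size would carry over to a core other than the one shared by these compounds.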